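Swapping one chlorine for fluorine on the aryl piperazine

The source may hold more compounds than are shown below. What is called first, only, known or untested is meant among the compounds shown, and "the series" means these compounds.

Of the compounds shown here, three built on a shared core have been measured in a functional assay on CHO cells with adenosine receptor A1 (Homo sapiens) as the target, read by cAMP accumulation and immunoassay, with a stated time of 6 min, tested at 1 uM; a lower number here means a stronger effect, a higher number a weaker effect of the compound at the concentration tested. Compound 1 `CC(C)N1CCN(Cc2csc(N)c2C(=O)c2ccc(Cl)cc2)CC1` carries an isopropyl on the ring nitrogen and gives 7.3%. Compound 2 `Nc1scc(CN2CCN(c3ccc(Cl)cc3Cl)CC2)c1C(=O)c1ccc(Cl)cc1` carries a 2,4-dichlorophenyl there instead and gives -54%, the lowest of the three numbers. Compound 3 `Nc1scc(CN2CCN(c3ccc(F)cc3Cl)CC2)c1C(=O)c1ccc(Cl)cc1` carries a 2-chloro-4-fluorophenyl and gives -39%. The replacement of isopropyl by an aryl group moves the number a long way: a number 61.3 percentage points lower from compound 1 to compound 2 (beyond the scatter) and a number 46.3 percentage points lower from compound 1 to compound 3 (beyond the scatter). Between the two aryl compounds the step is smaller: a number 15 percentage points higher from compound 2 to compound 3 (beyond the scatter).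

Compound 4 `Nc1scc(CN2CCN(c3ccc(Cl)cc3F)CC2)c1C(=O)c1ccc(Cl)cc1` has not yet been measured. It differs from compound 2 in one place: fluoro in place of chloro on an aromatic carbon. The change is thus the same kind of swap, fluoro in place of chloro, that separates compound 2 from compound 3, only at the other chlorine of the ring. Going by the values given here, the one step that bears on it is the modest rise from compound 2 to compound 3, so a step of similar size and direction is expected here, though the data give no way to tell how much the position matters. Compound 4 is therefore estimated at -42%, within -60% to -24%, meaning an expected step of a number 12 percentage points higher from compound 2 to compound 4 (beyond the scatter).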

Compound 4, a percentage reported as activity, at one concentration (the size of the read-out at that concentration, not a potency): -57%
Compound 4: middle estimate off by 15 percentage points, on the high side; measured number inside the range.
By their numbers in this assay, from the lowest: compounds 4 and 2 (each within the scatter of the next); then compound 3; then compound 1.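

In this assay, fluoro in place of chloro on an aromatic carbon ortho to a large group gives a number 3 percentage points lower from compound 2 to compound 4 (within the scatter), whereas the same swap at the other chlorine of the ring gave a number 15 percentage points higher from compound 2 to compound 3 (beyond the scatter). The swap therefore does not carry one fixed outcome across the ring: the two fluoro compounds hold the same two halogens in exchanged places, yet the exchange gives a number 18 percentage points lower from compound 3 to compound 4 (beyond the scatter). The large step away from isopropyl also holds for this third aryl group, with a number 64.3 percentage points lower from compound 1 to compound 4 (beyond the scatter), but nothing shown here bears on the reason for the difference between the two ring positions.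

The compounds shown leave open whether chloro and fluoro are special on the carbon ortho to a large group, or whether a methyl, a methoxy or a nitrile there would also give a read-out like those of compound 2 and compound 4. They also leave open what a plain phenyl on the ring nitrogen would give, with no halogen at either position.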